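Ester side-chain variation: cytotoxicity notes

A few compounds are considered here, and "the series" means these few. Any claim that something is new, unique, unknown or untested is made for them only; others in the source may bear on it.

Compound 1 `O=CCc1c(-c2ccccc2Cl)c2cc(Cl)ccc2[nH]c1=O` gives 120000 nM in an ADME assay on HepG2 2.2.15 cells (Homo sapiens) for cytotoxicity; on this read-out higher numbers stand for lower toxicity in this test and lower numbers for higher toxicity in this test; compound 2 `O=C(OCCc1c(-c2ccccc2Cl)c2cc(Cl)ccc2[nH]c1=O)c1ccco1` gives 98000 nM, and compound 3 `O=C(/C=C/c1ccccc1)OCCc1c(-c2ccccc2Cl)c2cc(Cl)ccc2[nH]c1=O` gives 230000 nM. Compound 3 stands highest of the three, with the step of a 2.3-fold higher number from compound 2 to compound 3 (0.37 log units; beyond the scatter) beyond the scatter and the gap to compound 1 within it. The step of a 1.2-fold lower number from compound 1 to compound 2 (0.09 log units; within the scatter) stayed within the scatter. Compound 4 `C/C=C/C(=O)OCCc1c(-c2ccccc2Cl)c2cc(Cl)ccc2[nH]c1=O` differs from compound 3 by methyl in place of phenyl on a double-bonded chain carbon bound to a double-bonded chain carbon. Going by the values given here, only the step from compound 2 to compound 3 bears on this change, and it was modest; the present change is smaller, so no step beyond the scatter is expected. The expected step is a 1.4-fold lower number from compound 3 to compound 4 (0.16 log units; within the scatter), within the scatter. For compound 4 the estimate is 160000 nM, ranging from 75000 nM to 340000 nM.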

Compound 4, half-maximal cytotoxic concentration: 30000 nM
Compound 4: the middle estimate sits 5.3-fold (0.73 log units) above what was measured, and the stated range ends above it.
By their numbers in this assay, from the lowest: compound 4; then compounds 2, 1 and 3 (each within the scatter of the next, the first and the last beyond it).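

In this assay, going by these compounds alone, the group on the double-bonded chain carbon clearly matters: a 7.7-fold lower number from compound 3 to compound 4 (0.88 log units; beyond the scatter) is the largest step so far, and it runs toward higher toxicity in this test. The esters also part ways, as a 3.3-fold lower number from compound 2 to compound 4 (0.51 log units; beyond the scatter) and a 4.0-fold lower number from compound 1 to compound 4 (0.60 log units; beyond the scatter) both lie beyond the scatter, so an ester side chain as such does not keep the number level with compound 1. On these data alone, whether an amine or a longer chain in place of methyl would restore the higher number remains open. Nothing at hand accounts for this drop.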